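A few compounds are considered here, and "the series" means these few. Any claim that something is new, unique, unknown or untested is made for them only; others in the source may bear on it.

Measured in a functional assay on K562 cells (Homo sapiens) for cytotoxicity, read by MTT assay, with a stated time of 48 h; a lower number here means a stronger inhibitor, a higher number a weaker inhibitor:
- Compound 1 `CCNC(=O)CC[C@H](NS(=O)(=O)c1ccc([N+](=O)[O-])cc1)C(=O)O`: > 500000 nM, a limit of the assay
- Compound 2 `CCCCNC(=O)CC[C@H](NS(=O)(=O)c1ccc([N+](=O)[O-])cc1)C(=O)O`: 19700 nM

Among the measured compounds shown here, compound 2 holds the only true number so far. Compound 1 is reported only as a limit.

Compound 3 `CC(C)CNC(=O)CC[C@H](NS(=O)(=O)c1ccc([N+](=O)[O-])cc1)C(=O)O` is an isomer of compound 2, with the same atoms joined differently: isopropyl in place of propyl on a saturated chain carbon bound to an amide-type nitrogen. It carries isopropyl in place of propyl on a saturated chain carbon bound to an amide-type nitrogen, which also reads as butyl to isobutyl.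

For the measured compounds named here, only one measured step bears on this change, an at least 25-fold lower number from compound 1 to compound 2 (1.40 log units; beyond the scatter). That large step touched the same amide substituent, but it added ethyl in place of hydrogen, whereas the new change adds no atoms. Its size therefore does not carry over, and only its location makes some movement conceivable. The expectation stays anchored on compound 2 at 19700 nM, and no step beyond the scatter is expected in this assay. The step expected is a 1.1-fold higher number from compound 2 to compound 3 (0.05 log units; within the scatter). Compound 3 is expected at about 22000 nM, with an estimated range of 8000 nM to 60000 nM.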

Compound 3, half-maximal inhibitory concentration: 42500 nM
Beside the measured number, compound 3's estimate is 1.9-fold (0.29 log units) below it; measured number inside the range.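

In this assay, moving from butyl to isobutyl adds no atoms yet gives a 2.2-fold higher number from compound 2 to compound 3 (0.33 log units; beyond the scatter), so this position on the amide responds to how its carbons are joined, whereas the earlier compounds had shown only a change in the substituent's size. Isobutyl nevertheless keeps a wide distance from the ethyl amide, with an at least 11-fold lower number from compound 1 to compound 3 (1.07 log units; beyond the scatter), so branching gives up only a modest part of the difference that separates the butyl amide from the ethyl amide. That distance is only a lower bound, as compound 1 is reported only as a limit: the limit of > 500000 nM in this assay, at which 1 of the 3 values shown sits.

With only ethyl, butyl and isobutyl on this amide nitrogen, the compounds shown leave open whether a longer chain such as hexyl, or a ring such as cyclohexyl, would lower the number further. They also leave open how the number would respond to an amine or a hydroxyl carried on this chain, so the reading here holds only for these three simple alkyl amides.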